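This account rests on a few compounds, and the source may have more. Where it says the series, first, only, none or still open, it means among the compounds named here.

Measured compounds:
compound 1 `CC(=O)OC[C@H]1O[C@@H](n2cc(-c3cn(Cc4ccccc4)nn3)c(=O)[nH]c2=O)C[C@@H]1OC(C)=O`: 88.7%
compound 2 `CC(=O)OC[C@H]1O[C@@H](n2cc(-c3cc(C)no3)c(=O)[nH]c2=O)C[C@@H]1OC(C)=O`: 90.8%
compound 3 `CC(C)(C)c1ccc(-c2cc(-c3cn([C@H]4C[C@H](O)[C@@H](CO)O4)c(=O)[nH]c3=O)on2)cc1`: 88%

In a functional assay on NUGC-3 cells (Homo sapiens) for cytotoxicity, read by sulforhodamine B assay, tested at 10 uM (on this read-out lower numbers stand for less inhibition and higher numbers for more inhibition at the one concentration tested (going by the name of the read-out)), compound 2 gives the highest of the three numbers, yet its gaps to compound 1 and to compound 3 both lie within the scatter, so the three compounds cannot be told apart on this read-out. Compound 4 `CC(=O)OC[C@H]1O[C@@H](n2cc(-c3cc(-c4ccccc4)no3)c(=O)[nH]c2=O)C[C@@H]1OC(C)=O` has not been measured; it differs from compound 2 in one place, (phenyl in place of methyl on an aromatic carbon). Among the compounds with values here, no step between measured compounds exists for comparison, so the expectation rests on the crowded range the three compounds share. Compound 4 is expected to stay in that range, with a step of a number 3.8 percentage points lower from compound 2 to compound 4 (within the scatter) that amounts to nothing beyond the scatter. The estimate for compound 4 is 87%, between 72% and 96%.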

Compound 4, a percentage reported as inhibition, at one concentration (the size of the read-out at that concentration, not a potency): 87.6%
Compound 4: middle estimate off by 0.6 percentage points, on the low side; the range from low to high includes it.
By their numbers in this assay, from the lowest: compounds 4, 3, 1 and 2 (each within the scatter of the next).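

In this assay, phenyl in place of methyl on the aromatic carbon next to the ring nitrogen gives a number 3.2 percentage points lower from compound 2 to compound 4 (within the scatter). This position of the five-membered ring therefore carries a six-membered aromatic ring as well as a methyl, with no difference that can be told from the scatter. No measurement shown gives a reason for this result. From the compounds shown here alone, whether an amine or a carboxylic acid on this carbon would stay in the same range remains open. With a single concentration, any differences in potency among these compounds also remain unresolved.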